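This account rests on a few compounds, and the source may have more. Where it says the series, first, only, none or still open, it means among the compounds named here.

Compound 1, `Cc1ccc(S(=O)(=O)NCc2ccc(CNC(=O)c3ccc(F)nc3)cc2)cc1`: in an assay on MDA-MB-231 cells for binding affinity to C-X-C chemokine receptor type 4 (Homo sapiens), read by fluorescence and microscopy, with stated times of 10 min and 30 min (a higher number here means that more compound is needed for the effect, a lower number that less compound is needed), compound 1 reaches only a limit, > 1000 nM.
Compound 2, `O=C(NCc1ccc(CNS(=O)(=O)c2cccc3ccccc23)cc1)c1ccc(F)cc1`: in this assay compound 2 gives 1000 nM.

Among the measured compounds shown here, compound 2 thus holds the only number measured here; the other value is the limit of > 1000 nM in this assay, at which 1 of the 2 values shown sits. Compound 3, `O=C(NCc1ccc(CNS(=O)(=O)c2ccccc2F)cc1)c1ccc(F)cc1`, differs from compound 2 in one place: 2-fluorophenyl in place of naphthalen-1-yl on a sulfonyl sulfur. For the measured compounds named here, no measured pair shows what exchanging the group on the sulfonyl sulfur does, so the expectation rests on compound 2 alone. The step of a 2.0-fold higher number from compound 2 to compound 3 (0.30 log units; within the scatter) is expected to be small, if anything toward more compound being needed. Compound 3 is estimated at 2000 nM, within 700 nM to 8000 nM.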

Compound 3, effective concentration (reported as EC, without a stated level of effect): 10 nM
Compound 3: middle estimate off by 200-fold (2.30 log units), on the high side; the measured number lies below the stated range.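

In this assay, the group on the sulfonyl sulfur proves to matter a great deal: 2-fluorophenyl in place of naphthalen-1-yl gives a 100-fold lower number from compound 2 to compound 3 (2.00 log units; beyond the scatter). The earlier compounds shown here offered no pair that could show this position moving the number at all. Nothing shown explains why this single change has so large an effect.

The change swaps two rings for one and also adds a fluorine, and the compounds shown do not separate these two differences. A plain phenyl group on the sulfonyl sulfur would be needed to tell them apart.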